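A few compounds are considered here, and "the series" means these few. Any claim that something is new, unique, unknown or untested is made for them only; others in the source may bear on it.

Measured so far:
- Compound 1 `O=C1C(=Cc2ccc(O)cc2)C(=O)N(c2ccc(Cl)cc2)N1c1ccc(Cl)cc1`: 34200 nM
- Compound 2 `O=C1C(=Cc2ccc(F)cc2)C(=O)N(c2ccc(Cl)cc2)N1c1ccc(Cl)cc1`: 35600 nM

Going by the values given here, in a functional assay on ECa-109 cells (Homo sapiens) for cytotoxicity, read by MTT assay, with a stated time of 72 h (a lower number here means a stronger inhibitor, a higher number a weaker inhibitor), compound 1 and compound 2 cannot be told apart, so compound 2 stands level with the only other measured compound. The next compound is compound 3 `COc1cccc(C=C2C(=O)N(c3ccc(Cl)cc3)N(c3ccc(Cl)cc3)C2=O)c1O`. It has 2-hydroxy-3-methoxyphenyl in place of 4-fluorophenyl on a double-bonded chain carbon bound to a double-bonded ring carbon.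

Among the compounds with values here, only one measured step bears on this change: a 1.0-fold higher number from compound 1 to compound 2 (0.02 log units; within the scatter). It swaps fluoro for hydroxy on an aromatic carbon and stays within the scatter. Within the data shown here, no measured compound carries a methoxy group, so this evidence is thin. No step beyond the scatter is expected in this assay. The estimate amounts to an expected 1.2-fold lower number from compound 2 to compound 3 (0.07 log units; within the scatter). For compound 3, the expected value is 30000 nM, with an estimated range of 12000 nM to 70000 nM.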

Compound 3, half-maximal inhibitory concentration: 39000 nM
Beside the measured number, compound 3's estimate is 1.3-fold (0.11 log units) below it; measured number inside the range.
By their numbers in this assay, from the lowest: compounds 1, 2 and 3 (each within the scatter of the next).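

In this assay, putting 2-hydroxy-3-methoxyphenyl in place of 4-fluorophenyl gives a 1.1-fold higher number from compound 2 to compound 3 (0.04 log units; within the scatter), and putting it in place of 4-hydroxyphenyl gives a 1.1-fold higher number from compound 1 to compound 3 (0.06 log units; within the scatter). Going by these compounds alone, the earlier step changed only one group on the aromatic ring, whereas these steps exchange the whole ring substituent on the double-bonded chain carbon, bringing in a methoxy group, and the three compounds still cannot be told apart. Nothing available explains why these changes leave the number level.

From the compounds shown here alone, no change at this position has yet produced a step beyond the scatter, so it remains unknown whether any group placed here can move the number. Going by these compounds, an amine or a carboxylic acid on this aromatic ring could test that, and the effect of changes elsewhere in the shared core also remains open.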